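The compounds below may be only part of what the source reports. "The series", "measured", "known", "first", "only" and "open" are said of these compounds alone.

The compounds share one core, a fused two-ring system carrying an amide chain that ends in a trifluoromethyl-substituted phenyl, and differ only in the amine on the aromatic carbon of that core. Compound 1 `CC(C)C(=O)NC1CCN(c2ccc3cc(NC(=O)CCc4ccc(C(F)(F)F)cc4)ccc3n2)C1` carries a 3-((isopropylcarbonyl)amino)pyrrolidin-1-yl group there; in a functional assay on HEK293 cells for activation of melanin-concentrating hormone receptor 1 (Rattus norvegicus), read by inositol phosphate accumulation (on this read-out higher numbers stand for an effect only at larger amounts of compound and lower numbers for an effect already at smaller amounts), compound 1 gives 90 nM. Compound 2 `CN(C)c1ccc2cc(NC(=O)CCc3ccc(C(F)(F)F)cc3)ccc2n1` carries a dimethylamino group, and in this assay compound 2 gives 110 nM. Compound 3 `O=C(CCc1ccc(C(F)(F)F)cc1)Nc1ccc2nc(N3CCCC3)ccc2c1` carries a pyrrolidin-1-yl group; in this assay compound 3 gives 320 nM; 320 nM (2 entries). Among the compounds with single numbers, compound 2 holds the highest, with compound 1 nearest, and the two lie within the scatter of each other; compound 3 gives a higher number than compound 2, but no single step links them. For the measured compounds named here, the only measured step at this position, a 1.2-fold higher number from compound 1 to compound 2 (0.09 log units; within the scatter), shows that exchanging one amine for another there stayed within the scatter. Compound 4 `Nc1ccc2cc(NC(=O)CCc3ccc(C(F)(F)F)cc3)ccc2n1` has not been measured; it differs from compound 2 by amino in place of dimethylamino on an aromatic carbon. Going by the values given here, since the one step that bears on this change is small, the change is expected to move this assay little, and a 1.4-fold higher number from compound 2 to compound 4 (0.13 log units; within the scatter) is the estimated step. Compound 4 is therefore expected to give 150 nM, between 60 nM and 400 nM.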

Compound 4, half-maximal effective concentration: 720 nM
Compound 4: middle estimate off by 4.8-fold (0.68 log units), on the low side, outside the stated range (above it).
By their numbers in this assay, from the lowest: compounds 1 and 2 (each within the scatter of the next); then compound 4.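

In this assay, for the compounds shown here, this position proves sensitive to the amine after all: amino in place of dimethylamino brings a 6.5-fold higher number from compound 2 to compound 4 (0.82 log units; beyond the scatter), whereas the one earlier exchange, dimethylamino for 3-((isopropylcarbonyl)amino)pyrrolidin-1-yl, brought only a 1.2-fold higher number from compound 1 to compound 2 (0.09 log units; within the scatter) and stayed within the scatter. Amino in place of the pyrrolidine group brings an 8.0-fold higher number from compound 1 to compound 4 (0.90 log units; beyond the scatter), so compound 1 and compound 2, whose attached nitrogen carries only carbon and no hydrogen, stand together while compound 4 stands apart; compound 3 also has such a nitrogen, but its two entries give no single number to set beside this pattern. The change removes 2 carbon atoms and adds 1 hydrogen-bond donor, yet nothing in the data given says which of these differences, if either, accounts for the step.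

From the compounds shown here alone, whether methylamino, with one carbon on the nitrogen, would sit with compound 2 or with compound 4 remains open. So does how a methoxy or a hydroxyl group would behave on this aromatic carbon, where the compounds shown carry only nitrogen-linked groups.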